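Extending an Alkoxy Chain on a Shared Diaryl Core

The source may report more compounds than this note shows. Statements on the series, on what has been measured and on what is new or still open speak of the compounds shown alone.

The three measured compounds share one core. Compound 1 `CCCCCCNc1cc(-c2ccccc2)c(-c2ccccc2)nn1` gives 24000 nM in an assay on microsomes from liver for inhibition of sterol O-acyltransferase 1 (Rattus norvegicus); a lower number here means a stronger inhibitor, a higher number a weaker inhibitor. Compound 2 `CCCCCCOc1cc(-c2ccccc2)c(-c2ccccc2)nn1` gives 72000 nM in this assay, and compound 3 `CCCCCCCOc1cc(-c2ccccc2)c(-c2ccccc2)nn1` gives 58000 nM in this assay. Compound 3 stands second highest of the three numbers; its nearest neighbour is compound 2, within the scatter, and the furthest is compound 1, beyond it. The steps of a 3.0-fold higher number from compound 1 to compound 2 (0.48 log units; beyond the scatter) and a 2.4-fold higher number from compound 1 to compound 3 (0.38 log units; beyond the scatter) were modest and swapped the group on the aromatic carbon rather than lengthening the chain.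

Compound 4 `CCCCCCCCOc1cc(-c2ccccc2)c(-c2ccccc2)nn1` differs from compound 3 by methyl in place of hydrogen on a saturated chain carbon, seven bonds along the chain from an oxygen on an aromatic ring. Within the data shown here, the one measured step that bears on this kind of change is a 1.2-fold lower number from compound 2 to compound 3 (0.09 log units; within the scatter), which stayed within the scatter. Compound 4 is therefore expected to show no step beyond the scatter, a 1.2-fold lower number from compound 3 to compound 4 (0.06 log units; within the scatter). The value of compound 4 in this assay is estimated at 50000 nM, with a range from 25000 nM to 100000 nM.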

Compound 4, half-maximal inhibitory concentration: 104000 nM
Compound 4: middle estimate off by 2.1-fold (0.32 log units), on the low side, and the stated range ends below it.
By their numbers in this assay, from the lowest: compound 1; then compounds 3, 2 and 4 (each within the scatter of the next).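

In this assay, among these compounds, methyl in place of hydrogen on a saturated chain carbon, seven bonds along the chain from an oxygen on an aromatic ring, gives a step that stays within the scatter (a 1.8-fold higher number from compound 3 to compound 4 (0.25 log units; within the scatter)), and the ethyl change from the hexyloxy chain does the same (a 1.4-fold higher number from compound 2 to compound 4 (0.16 log units; within the scatter)), so no step among compounds 2, 3 and 4 separates these chains. Swapping the hexylamino group for the octyloxy group gives a step beyond the scatter (a 4.3-fold higher number from compound 1 to compound 4 (0.64 log units; beyond the scatter)), so the only separations shown remain those between compound 1 and the three alkoxy compounds. No supporting measurement is available to explain these numbers.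

From the compounds shown here alone, whether a chain longer than octyloxy would move beyond the scatter remains open. So does the effect of a heptylamino or octylamino chain, or of an amine or carboxylic acid at the chain end.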